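Swapping a thiophene for a cyanophenyl on the seven-membered ring

A few compounds are considered here, and "the series" means these few. Any claim that something is new, unique, unknown or untested is made for them only; others in the source may bear on it.

Compound 3 `C=CC(=O)N1C(=O)CC(c2cccs2)Sc2ccccc21` was tested in a functional assay on Raji cells (Homo sapiens) for cytotoxicity, read by CCK-8 assay, with a stated time of 24 h (a lower number here means a stronger inhibitor, a higher number a weaker inhibitor), and there compound 3 gives 659000 nM. Among the three compounds measured so far this is the highest number. Its nearest neighbour is compound 2 `C=CC(=O)N1C(=O)CCSc2ccccc21`, which in this assay gives 581000 nM; the compound furthest from it is compound 1 `C=CC(=O)N1C(=O)CC(c2ccc(C(=O)OC)cc2)Sc2ccccc21`, which in this assay gives 89600 nM, a gap beyond the scatter.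

Compound 4 `C=CC(=O)N1C(=O)CC(c2ccc(C#N)cc2)Sc2ccccc21` has not yet been measured. It differs from compound 3 in one place: 4-cyanophenyl in place of thiophen-2-yl on a saturated ring carbon.

For the measured compounds named here, only one measured step touches the same saturated ring carbon: a 1.1-fold higher number from compound 2 to compound 3 (0.05 log units; within the scatter). It lies within the scatter, so putting a thiophen-2-yl group there in place of hydrogen changed nothing that can be seen. Going by the values given here, a more useful comparison is compound 1, the only measured compound carrying a substituted phenyl ring on that saturated ring carbon, and it has the lowest of the three numbers. Among the compounds with values here, since compound 4 also carries a substituted phenyl ring there, 4-cyanophenyl, the expectation is a move downward, of roughly a 4.4-fold lower number from compound 3 to compound 4 (0.64 log units; beyond the scatter), though with only one such example the size is uncertain. Compound 4 is therefore expected to give about 150000 nM, within a range from 50000 nM to 450000 nM.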

Compound 4, half-maximal inhibitory concentration: 84500 nM
For compound 4 the middle estimate is 1.8-fold (0.25 log units) above the measured one; the measured number falls inside the stated range.
By their numbers in this assay, from the lowest: compounds 4 and 1 (each within the scatter of the next); then compounds 2 and 3 (each within the scatter of the next).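

In this assay the saturated ring carbon next to the ring sulfur clearly responds to the group it carries: replacing thiophen-2-yl with 4-cyanophenyl gives a 7.8-fold lower number from compound 3 to compound 4 (0.89 log units; beyond the scatter) and replacing hydrogen with 4-cyanophenyl gives a 6.9-fold lower number from compound 2 to compound 4 (0.84 log units; beyond the scatter), whereas replacing hydrogen with thiophen-2-yl showed no visible change (a 1.1-fold higher number from compound 2 to compound 3 (0.05 log units; within the scatter)). The drop seen with compound 1 is not a one-off. A second substituted phenyl ring now gives it, and the choice between cyano and methoxycarbonyl on that ring stays within the scatter (a 1.1-fold lower number from compound 1 to compound 4 (0.03 log units; within the scatter)), while compound 3 shows that an aromatic ring on this carbon does not bring the drop by itself. Nothing available explains why the two kinds of ring differ here.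

From the compounds shown here alone, it remains open whether a plain phenyl ring on this carbon would give the same drop, or whether the ring needs a substituent such as cyano or methoxycarbonyl. The compounds shown also leave unsettled how an amine, a carboxylic acid or a longer chain on that phenyl ring would fare.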